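The source may hold more compounds than are shown below. What is called first, only, known or untested is meant among the compounds shown, and "the series" means these compounds.

Measured compounds in an ADME assay on MDBK cells (Bos taurus) for cytotoxicity; a lower number here means that less compound is tolerated, a higher number that more compound is tolerated:
- compound 1 `Clc1ccc(Cn2ccc3nc(-c4ccccc4)nc-3c2)cc1`: > 100000 nM
- compound 2 `FC(F)(F)Oc1ccc(Cn2ccc3nc(-c4ccccc4)nc-3c2)cc1`: 66000 nM

In this assay compound 1 gives > 100000 nM, which is a limit of the assay rather than a number (the limit of > 100000 nM in this assay, at which 1 of the 2 values shown sits). In this assay compound 2 gives 66000 nM. The step of an at least 1.5-fold lower number from compound 1 to compound 2 (0.18 log units; that floor lies within the scatter) exchanges one substituent on an aromatic carbon and does not leave the scatter.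

Compound 3 `Clc1ccc(Cn2ccc3nc(-c4ccccc4)nc-3c2)s1` differs from compound 1 by 5-chlorothiophen-2-yl in place of 4-chlorophenyl on a saturated chain carbon bound to an aromatic nitrogen. Among the measured compounds shown here, no measured step exchanges one ring for another at this position; the only measured step, from compound 1 to compound 2, concerns a different part of the molecule and is within the scatter, so it bears on compound 3 only indirectly. On this basis no step beyond the scatter is expected for compound 3 in this assay; compound 3 is expected to sit near the limit of compound 1, with the estimated step of an at least 1.1-fold lower number from compound 1 to compound 3 (0.04 log units; that floor lies within the scatter).

The estimate for compound 3 in this assay is 90000 nM, with a range from 35000 nM to 200000 nM.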

Compound 3, half-maximal cytotoxic concentration: > 100000 nM
Compound 3: only a limit was reported (the forecaster's own chance of this, stated with the estimate: 55%); at least 1.1-fold (0.04 log units) between middle value and limit.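

In this assay, compound 1 and compound 3 both give a limit rather than a number, so no step between them can be read: the limit of > 100000 nM in this assay, at which 2 of the 3 values shown sit.

The compounds shown leave open whether 5-chlorothiophen-2-yl in place of 4-chlorophenyl shifts tolerance at all.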